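A few compounds are considered here, and "the series" means these few. Any claim that something is new, unique, unknown or untested is made for them only; others in the source may bear on it.

Measured so far:
Compound 1, `CC1CCN(c2nc(C(F)(F)Cl)ccc2CNC(=O)C(C)c2ccc(NS(C)(=O)=O)c(F)c2)CC1`: 0.3 nM
Compound 2, `CC(C(=O)NCc1ccc(C(F)(F)Cl)nc1OC1CCCCC1)c1ccc(NS(C)(=O)=O)c(F)c1`: 0.9 nM

Within the data shown here, compound 2 holds the highest of the two numbers recorded in an assay on CHO cells for antagonist activity at transient receptor potential cation channel subfamily V member 1 (Homo sapiens), read by FLIPR; on this read-out lower numbers stand for stronger inhibition and higher numbers for weaker inhibition; its nearest neighbour is compound 1, and the only measured step, a 3.0-fold higher number from compound 1 to compound 2 (0.48 log units; beyond the scatter), replaced a 4-methylpiperidin-1-yl group with a cyclohexyloxy group on an aromatic carbon.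

Compound 3, `CC(C(=O)NCc1ccc(C(F)(F)Cl)nc1SC1CCCCC1)c1ccc(NS(C)(=O)=O)c(F)c1`, has not yet been measured. It differs from compound 2 in one place: cyclohexylsulfanyl in place of cyclohexyloxy on an aromatic carbon. The ring and its size stay the same; only the oxygen linking it to the aromatic carbon next to the ring nitrogen gives way to sulfur.

Among the measured compounds shown here, no measured step bears directly on an exchange of oxygen for sulfur. For the measured compounds named here, the one step in hand concerns a different group at the same place, and it was modest. By analogy, compound 3 is expected to differ from compound 2 by at most a similarly modest step in this assay, and a step that stays within the scatter is a real possibility. The estimate therefore places compound 3 near 1.5 nM, with a range from 0.5 nM to 5 nM, implying a step of a 1.7-fold higher number from compound 2 to compound 3 (0.22 log units; within the scatter) that is expected to be small, and if beyond the scatter, towards a higher number.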

Compound 3, inhibition constant: 3 nM
Beside the measured number, compound 3's estimate is 2.0-fold (0.30 log units) below it; the range from low to high includes it.
By their numbers in this assay, from the lowest: compound 1; then compound 2; then compound 3.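

In this assay, the change from cyclohexyloxy to cyclohexylsulfanyl on the aromatic carbon next to the ring nitrogen gives a 3.3-fold higher number from compound 2 to compound 3 (0.52 log units; beyond the scatter) even though the six-membered ring stays in place, so the linking atom alone moves the number at this position. Across the three groups at this carbon, the numbers run from 4-methylpiperidin-1-yl through cyclohexyloxy to cyclohexylsulfanyl, and the two ends of that series are separated by a 10-fold higher number from compound 1 to compound 3 (1.00 log units; beyond the scatter) which is a wider span than the first step showed. No measurement shown explains why compound 3 has a higher number than compound 2.

Going by these compounds, what remains open is how a nitrogen link, as in a cyclohexylamino group, would compare with the oxygen and sulfur links, which would show whether compound 2 and compound 3 mark the limits of what a linking atom can do here. On these data alone, it is also open whether the carbon ring is needed at all, since an open chain such as hexyloxy would separate the contribution of the ring from that of the link.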